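This account rests on a few compounds, and the source may have more. Where it says the series, first, only, none or still open, it means among the compounds named here.

The measured compounds and their numbers:

compound 1 `Cc1ccc(/C=C2\S/C(=N\c3csc(-c4ccc(Cl)cc4)c3)NC2=O)cc1`: 900 nM
compound 2 `CN(C)c1ccc(/C=C2\S/C(=N\c3csc(-c4ccc(Cl)cc4)c3)NC2=O)cc1`: 800 nM

Both compounds share the same core and differ only in the aromatic group hanging from the double-bonded chain carbon. In a functional assay on MDA-MB-231 cells (Homo sapiens) for cytotoxicity, read by MTT assay, with a stated time of 72 h (a lower number here means a stronger inhibitor, a higher number a weaker inhibitor), compound 2 gives 800 nM, and compound 1 gives 900 nM; the two numbers lie within the scatter of each other, so neither compound can be called the stronger inhibitor.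

Compound 3 `O=C1N/C(=N/c2csc(-c3ccc(Cl)cc3)c2)S/C1=C\c1ccc2ccccc2c1` differs from compound 2 in one place: naphthalen-2-yl in place of 4-(dimethylamino)phenyl on a double-bonded chain carbon bound to a double-bonded ring carbon. Among the compounds with values here, only one measured step bears on this kind of change, the exchange at the same position recorded as a 1.1-fold lower number from compound 1 to compound 2 (0.05 log units; within the scatter). There, swapping one substituent on the aromatic ring for another left the number essentially where it was. Within the data shown here, replacing the whole ring with a larger, two-ring aromatic group is a bigger structural move than that single step, so some uncertainty remains, but the one available comparison gives no reason to expect a shift beyond the scatter in this assay. The expected step is no change at the digits printed from compound 2 to compound 3 (within the scatter), that is, essentially no change. Compound 3 is therefore estimated at 800 nM, with a range from 300 nM to 2500 nM.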

Compound 3, half-maximal inhibitory concentration: 1800 nM
Compound 3: the middle estimate sits 2.3-fold (0.35 log units) below what was measured; low and high end bracket the measured number.
By their numbers in this assay, from the lowest: compounds 2, 1 and 3 (each within the scatter of the next, the first and the last beyond it).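

In this assay, within the data shown here, the exchange of 4-(dimethylamino)phenyl for naphthalen-2-yl on a double-bonded chain carbon bound to a double-bonded ring carbon gives a 2.3-fold higher number from compound 2 to compound 3 (0.35 log units; beyond the scatter), the only step at this position among the three compounds that passes beyond the scatter. The same two-ring group in place of 4-methylphenyl gives a 2.0-fold higher number from compound 1 to compound 3 (0.30 log units; within the scatter) and so cannot be told apart from that single-ring compound, which means the position shows only a modest response to replacing the whole aromatic group, and that response is seen against one of the two single-ring compounds, not both. Nothing measured here accounts for the difference between these two steps.

The compounds shown leave open whether the modest step comes from having a second fused ring or from losing the dimethylamino group, a question that a plain phenyl or a 4-aminophenyl group at this position would help to separate. They also leave open how a pyridinyl ring, a 4-carboxyphenyl group or the naphthalen-1-yl isomer would read at the same place.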